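This account rests on a few compounds, and the source may have more. Where it says the series, first, only, none or still open, it means among the compounds named here.

Working notes on the series, measured in an ADME assay on L02 cells (Homo sapiens) for cytotoxicity, read by MTT assay, with a stated time of 24 h; on this read-out higher numbers stand for weaker inhibition and lower numbers for stronger inhibition:

- compound 1 `CN1C/C(=C\c2ccc(C(F)(F)F)cc2)C(=O)/C(=C/c2ccccc2F)C1`: 18600 nM
- compound 2 `CN1C/C(=C\c2cccc([N+](=O)[O-])c2)C(=O)/C(=C/c2ccccc2F)C1`: 13500 nM
- compound 3 `COc1cc(/C=C2\CN(C)C/C(=C\c3ccc(Cl)c(Cl)c3)C2=O)cc(OC)c1OC`: 18400 nM

Compound 2, at 13500 nM, lies within the scatter of both compound 1 and compound 3, so the three values form a single band. Compound 4 `CN1C/C(=C\c2ccc(Br)cc2)C(=O)/C(=C/c2cccc([N+](=O)[O-])c2)C1` differs from compound 2 by 4-bromophenyl in place of 2-fluorophenyl on a double-bonded chain carbon bound to a double-bonded ring carbon. Within the data shown here, no measured pair isolates this change. The aryl groups of compound 1 at 18600 nM and compound 3 at 18400 nM differ from those of compound 2, yet both values stay within its scatter. In this assay, no step beyond the scatter is therefore expected. The expected step is a 1.1-fold higher number from compound 2 to compound 4 (0.05 log units; within the scatter). For compound 4 the estimated value is 15000 nM, with an expected range of 7000 nM to 32000 nM.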

Compound 4, half-maximal inhibitory concentration: 9850 nM
Compound 4: the middle estimate sits 1.5-fold (0.18 log units) above what was measured, and the stated range covers the measured number.
By their numbers in this assay, from the lowest: compounds 4, 2, 3 and 1 (each within the scatter of the next).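

In this assay the first pair differing in one place gives a 1.4-fold lower number from compound 2 to compound 4 (0.14 log units; within the scatter) and so shows no separation beyond the scatter. At this position on a double-bonded chain carbon bound to a double-bonded ring carbon, 4-bromophenyl and 2-fluorophenyl cannot be told apart on this read-out. Nothing at hand bears on the reason for this result.

This is a single exchange between two halogen-bearing phenyl groups. On these data alone, whether a carboxylic acid or an amine on the phenyl ring at this position would give a step beyond the scatter remains open.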